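The source may hold more compounds than are shown below. What is called first, only, known or untested is meant among the compounds shown, and "the series" means these compounds.

Compound 1 `O=C(Nc1ccccc1)c1cc2ccccc2oc1=O` carries no substituent on the aniline ring, and in an in vitro assay on BTI-TN-5B1-4 cells for inhibition of Amine oxidase [flavin-containing] B (Homo sapiens), read by fluorescence (a lower number here means a stronger inhibitor, a higher number a weaker inhibitor), compound 1 gives 760 nM. Compound 2 `CCc1ccc(NC(=O)c2cc3ccccc3oc2=O)cc1` bears an ethyl group there, and in this assay compound 2 gives 890 nM. Compound 3 `COc1ccc(NC(=O)c2cc3ccccc3oc2=O)cc1` bears a methoxy group, and in this assay compound 3 gives 820 nM. Among these three numbers compound 3 stands second highest, nearest to compound 1 and furthest from compound 2, with both gaps within the scatter. Compound 4 `O=C(Nc1ccc(F)cc1)c1cc2ccccc2oc1=O` differs from compound 3 by fluoro in place of methoxy on an aromatic carbon. Within the data shown here, two measured steps bear on this position: a 1.1-fold higher number from compound 1 to compound 3 (0.03 log units; within the scatter) and a 1.1-fold lower number from compound 2 to compound 3 (0.04 log units; within the scatter), and both lie within the scatter, so the substituent at this position has so far left the number essentially unchanged across hydrogen, ethyl and methoxy. The expectation for compound 4 is therefore no step beyond the scatter, that is a 1.0-fold lower number from compound 3 to compound 4 (0.01 log units; within the scatter), and compound 4 is expected to give 800 nM in this assay, with a range from 400 nM to 1600 nM.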

Compound 4, half-maximal inhibitory concentration: 67 nM
For compound 4 the middle estimate is 12-fold (1.08 log units) above the measured one, and the stated range ends above it.
By their numbers in this assay, from the lowest: compound 4; then compounds 1, 3 and 2 (each within the scatter of the next).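

In this assay this position proves not to be indifferent to its substituent, since the change from methoxy to fluoro gives a 12-fold lower number from compound 3 to compound 4 (1.09 log units; beyond the scatter) and the change from ethyl to fluoro gives a 13-fold lower number from compound 2 to compound 4 (1.12 log units; beyond the scatter) while the change from hydrogen to fluoro gives an 11-fold lower number from compound 1 to compound 4 (1.05 log units; beyond the scatter) in the same direction. Hydrogen, ethyl and methoxy lie within the scatter of one another, so the large steps go with the entry of fluoro rather than with the loss of methoxy or ethyl, and compound 4 alone stands apart from the other three. Nothing at hand accounts for this difference.

On these data alone, what chloro, bromo, an amine or a carboxylic acid would do at this position stays open, so the step cannot yet be assigned to fluoro alone or to halogens more widely. Also open, as far as these compounds go, is whether fluoro on another carbon of this ring would give a step of this kind.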